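Hydroxyphenyl placement across a shared pyridine-free diaryl series

The source may report more compounds than this note shows. Statements on the series, on what has been measured and on what is new or still open speak of the compounds shown alone.

Compound 1 `Oc1cccc(-c2cc(-c3ccc(F)cc3)cc(-c3cccc(O)c3)n2)c1` carries two 3-hydroxyphenyl groups; compound 2 `Oc1ccc(-c2cc(-c3ccc(F)cc3)cc(-c3cccc(O)c3)n2)cc1` differs from it by 4-hydroxyphenyl in place of 3-hydroxyphenyl on an aromatic carbon. Compound 3 `Oc1ccc(-c2cc(-c3ccccc3OC(F)(F)F)cc(-c3cccc(O)c3)n2)cc1` has a different core, and its partner compound 4 `Oc1ccc(-c2cc(-c3ccccc3OC(F)(F)F)cc(-c3ccc(O)cc3)n2)cc1` is not yet measured.

In a functional assay on HeLa cells (Homo sapiens) for inhibition (a lower number here means a stronger inhibitor, a higher number a weaker inhibitor), compound 1 gives 1280 nM. Compound 2 gives 8080 nM, so the change 4-hydroxyphenyl in place of 3-hydroxyphenyl on an aromatic carbon produced a 6.3-fold higher number from compound 1 to compound 2 (0.80 log units; beyond the scatter). Compound 3 gives 5800 nM; against compound 1 the difference between the two cores is not broken down here.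

The change from compound 3 to compound 4, (4-hydroxyphenyl in place of 3-hydroxyphenyl on an aromatic carbon), is the same kind of change as that from compound 1 to compound 2, though not the same: in compound 1 the place is meta to a 3-hydroxyphenyl group and meta to a 4-fluorophenyl group, whereas in compound 3 it is meta to a 4-hydroxyphenyl group and meta to a large group.

For compound 4 a step of similar direction, a 4.3-fold higher number from compound 3 to compound 4 (0.63 log units; beyond the scatter), is expected, resting on a 6.3-fold higher number from compound 1 to compound 2 (0.80 log units; beyond the scatter) in compounds 1 and 2. Compound 4 is estimated at 25000 nM, with a range of 9000 nM to 70000 nM.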

Compound 4, half-maximal inhibitory concentration: 44600 nM
The estimate for compound 4 lay 1.8-fold (0.25 log units) below the measured number; low and high end bracket the measured number.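

In this assay, 4-hydroxyphenyl in place of 3-hydroxyphenyl on the second core gives a 7.7-fold higher number from compound 3 to compound 4 (0.89 log units; beyond the scatter), and this step agrees with the one seen on the first core: the same change on two cores in this assay, a 6.3-fold higher number (0.80 log units; beyond the scatter) from compound 1 to compound 2 and a 7.7-fold higher number (0.89 log units; beyond the scatter) from compound 3 to compound 4, 1.2-fold (0.09 log units) apart, within the scatter of two such steps. The change therefore carries over between these two cores in direction and in size, although the cores differ in the group that is 4-fluorophenyl in compound 1. This rests on two pairs only, so it does not show that the step would hold on any further core, and it says nothing about why the 4-hydroxyphenyl group gives the higher number.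

Still open, from the compounds shown here alone, is whether the hydroxyl itself matters, which a methoxy group, an amine or a carboxylic acid in its place in this assay would address. Also open, going by these compounds, is the size of the step on a core carrying some other group, such as a nitrile, where these two cores differ.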